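Compound 3 to compound 4: bromo in place of hydrogen

A few compounds are considered here, and "the series" means these few. Any claim that something is new, unique, unknown or untested is made for them only; others in the source may bear on it.

In an ADME assay on NIH3T3 cells (Mus musculus) for cytotoxicity, read by XTT assay, with a stated time of 24 h (on this read-out lower numbers stand for stronger inhibition and higher numbers for weaker inhibition), compound 3 (`Cc1ccc(C2=NN(c3nc(-c4ccccc4)cs3)C(c3ccc(F)cc3)C2)s1`) gives > 500 ug/mL as a limit, not a number. Compound 1 (`Cc1ccc(-c2csc(N3N=C(c4ccc(C)s4)CC3c3ccc(F)cc3)n2)cc1`) gives > 500 ug/mL as a limit too. Compound 2 (`Cc1ccc(C2=NN(c3nc(-c4ccc(F)cc4)cs3)C(c3ccc(F)cc3)C2)s1`) likewise gives > 500 ug/mL as a limit. Compound 3 therefore stands with the other two at the limit of > 500 ug/mL in this assay, at which 3 of the 3 values shown sit, and cannot be ranked against them. Compound 4 (`Cc1ccc(C2=NN(c3nc(-c4ccc(Br)cc4)cs3)C(c3ccc(F)cc3)C2)s1`) differs from compound 3 by one change: bromo in place of hydrogen on an aromatic carbon with bromo in place of hydrogen on an aromatic carbon. Within the data shown here, the steps that bear on it are a step that the two limits leave unreadable from compound 2 to compound 3 and a step that the two limits leave unreadable from compound 1 to compound 3 together with a step that the two limits leave unreadable from compound 1 to compound 2 and none gives a size or a direction. In this assay the expected change is a step that the limit leaves unreadable from compound 3 to compound 4 with no direction expected. Compound 4 is estimated at 600 ug/mL with an expected range of 300 ug/mL to 1200 ug/mL and will probably be reported only as a limit.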

Compound 4, half-maximal inhibitory concentration: > 500 ug/mL
Compound 4: no number, only a limit; the forecaster's own chance of this, stated with the estimate: 85%; the middle value lies beyond the limit too.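

In this assay compound 4 gives > 500 ug/mL, a limit and not a number, so no step linking it to compound 1, compound 2 or compound 3 can be read: the limit of > 500 ug/mL in this assay, at which 4 of the 4 values shown sit.

The compounds shown leave open whether methyl, fluoro, hydrogen and bromo at this place differ at all.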